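Cyclobutyl in place of isopropoxymethyl on the chain

The source may hold more compounds than are shown below. What is called first, only, known or untested is meant among the compounds shown, and "the series" means these compounds.

Measured so far:
compound 1 `COc1cc(Cc2nc3c(N)ncnc3n2CCCCCO)cc(OC)c1OC`: 84900000 nM
compound 2 `CCCCn1c(Cc2cc(OC)c(OC)c(OC)c2)nc2c(N)nc(F)nc21`: 185000000 nM
compound 3 `COc1cc(Cc2nc3c(N)nc(F)nc3n2CCOC(C)C)cc(OC)c1OC`: 769000000 nM

In a functional assay on MCF7 cells (Homo sapiens) for cytotoxicity (a higher number here means that more compound is needed for the effect, a lower number that less compound is needed), compound 3 gives the highest number of the three, with compound 2 nearest and compound 1 furthest. Compound 4 `COc1cc(Cc2nc3c(N)nc(F)nc3n2CC2CCC2)cc(OC)c1OC` differs from compound 3 in one place: cyclobutyl in place of isopropoxymethyl on a saturated chain carbon bound to an aromatic nitrogen. Within the data shown here, only one measured step touches the same chain, a 4.2-fold higher number from compound 2 to compound 3 (0.62 log units; beyond the scatter), where ethyl went to isopropoxy; compound 4 takes the chain back toward a hydrocarbon chain, with no acceptor in it, which is closer to what compound 2 carries. Compound 1 cannot be compared directly, as it differs in more than one place. The step from compound 3 to compound 4 is therefore expected to run downward, partly undoing the step to compound 3, and to land near the number of compound 2, with the step of a 2.6-fold lower number from compound 3 to compound 4 (0.41 log units; beyond the scatter) expected. For compound 4 a value of 300000000 nM is estimated, within a range from 120000000 nM to 750000000 nM.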

Compound 4, half-maximal effective concentration: 109000000 nM
For compound 4 the middle estimate is 2.8-fold (0.44 log units) above the measured one, and the stated range ends above it.
By their numbers in this assay, from the lowest: compounds 1, 4 and 2 (each within the scatter of the next, the first and the last beyond it); then compound 3.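

In this assay the cyclobutyl group takes the number down by a 7.1-fold lower number from compound 3 to compound 4 (0.85 log units; beyond the scatter), so this position responds to a change of the whole side chain and not only to the step that first introduced isopropoxy. Cyclobutyl in place of propyl gives a 1.7-fold lower number from compound 2 to compound 4 (0.23 log units; within the scatter), so the ring and the open chain are not told apart here, and among these three compounds only compound 3, which carries the hydrogen-bond acceptor in its chain, stands apart from the others beyond the scatter. Nothing available accounts for these differences.

From the compounds shown here alone, whether the ether oxygen itself or the branched isopropyl end sets compound 3 apart remains open. Also open, going by these compounds, is how an amine, a carboxylic acid or a longer chain at this position would read in this assay.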